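Chlorine moved on the aryl group of compound 3

A few compounds are considered here, and "the series" means these few. Any claim that something is new, unique, unknown or untested is made for them only; others in the source may bear on it.

The measured compounds are:
compound 1 `Oc1cccc(-c2cc(-c3cccnc3)nc(-c3cccc(Cl)c3)c2)c1`, "not determined" (no result reported);
compound 2 `Oc1cccc(-c2cc(-c3cccc(Cl)c3)nc(-c3ccco3)c2)c1`, 3570 nM;
compound 3 `Oc1cccc(-c2cc(-c3ccc(Cl)cc3)nc(-c3ccsc3)c2)c1`, 11500 nM.

Within the data shown here, in a functional assay on T47D cells (Homo sapiens) for cytotoxicity, read by CCK-8 assay and cell counting, with a stated time of 2 days (on this read-out lower numbers stand for stronger inhibition and higher numbers for weaker inhibition), only two numbers stand, and compound 3 holds the higher of them, its value of 11500 nM lying beyond the scatter from the number of compound 2, which gives 3570 nM in this assay. For compound 1 no number is available, so it offers no comparison.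

Compound 4 `Oc1cccc(-c2cc(-c3ccsc3)nc(-c3cccc(Cl)c3)c2)c1` keeps every atom of compound 3 and differs only in how they are joined: 3-chlorophenyl in place of 4-chlorophenyl on an aromatic carbon. The change is a 3-chlorophenyl in place of a 4-chlorophenyl on an aromatic carbon next to the ring nitrogen, meta to a 3-hydroxyphenyl group and meta to a thiophen-3-yl group. Among the measured compounds shown here, no pair of measured compounds isolates this change, since compounds 1 and 2 carry their 3-chlorophenyl with other partner groups as well. The expectation is therefore cautious: in this assay the step is estimated as a 1.6-fold lower number from compound 3 to compound 4 (0.22 log units; within the scatter), a shift small enough to sit near the scatter, leaning toward a lower number. Compound 4 is estimated at 7000 nM in this assay, with a range from 2500 nM to 20000 nM.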

Compound 4, half-maximal inhibitory concentration: 3540 nM
Estimate against measurement, compound 4: 2.0-fold (0.30 log units) above, and the stated range covers the measured number.
By their numbers in this assay, from the lowest: compounds 4 and 2 (each within the scatter of the next); then compound 3.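

Within this assay, the position next to the ring nitrogen proves sensitive to where the chlorine sits on the aryl group: 3-chlorophenyl in place of 4-chlorophenyl gives a 3.2-fold lower number from compound 3 to compound 4 (0.51 log units; beyond the scatter), a change that keeps every atom and alters only how they are joined. The earlier compounds shown here could not show this, since none of them isolated the placement of the chlorine. With 3-chlorophenyl held constant, thiophen-3-yl in place of furan-2-yl gives a 1.0-fold lower number from compound 2 to compound 4 (0.00 log units; within the scatter), so the two partner rings cannot be told apart here, and the gap seen earlier between the two measured compounds now traces to the chlorine placement rather than to the partner ring alone. Nothing available explains why the placement of the chlorine matters in this way.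

Whether the same step holds alongside furan-2-yl remains open, as the compounds shown pair 4-chlorophenyl only with thiophen-3-yl. Also open, on these data alone, is how this position would respond if an amine or a carboxylic acid took the place of the chlorine on the phenyl ring.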